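The source may hold more compounds than are shown below. What is called first, only, known or untested is meant among the compounds shown, and "the series" means these compounds.

Compound 1, `C#Cc1cccc(Nc2nc(Cl)nc3cc(OC)c(OC)cc23)c1`, gives 7500 nM in a functional assay on SK-HEP1 cells (Homo sapiens) for cytotoxicity, read by MTT assay, with a stated time of 48 h; a lower number here means a stronger inhibitor, a higher number a weaker inhibitor.
Compound 2, `COc1cc2nc(Cl)nc(Nc3cccc(Cl)c3)c2cc1OC`, gives 16500 nM in this assay.
For compound 3, `C#Cc1cccc(Nc2ccnc(Cl)n2)c1`, this assay reports only a limit, > 40000 nM.

Compounds 1 and 2 share one core, while compound 3 and the not yet measured compound 4, `Clc1cccc(Nc2ccnc(Cl)n2)c1`, share a smaller one; the difference between the two cores is not broken down here. Within the first core, the change chloro in place of ethynyl on an aromatic carbon produced a 2.2-fold higher number from compound 1 to compound 2 (0.34 log units; beyond the scatter). The step from compound 3 to compound 4 is the same kind of change, (chloro in place of ethynyl on an aromatic carbon), though the surroundings of the place differ in wording: in the first pair the group sits "meta to a large group", in the second "meta to a group of 8 heavy atoms". Compound 3 already sits at the limit of > 40000 nM in this assay, at which 1 of the 3 values shown sits, so the starting point for compound 4 is not a number. For compound 4 the step is expected to be a step that the limit leaves unreadable from compound 3 to compound 4, resting on compound 1 to compound 2, where a 2.2-fold higher number from compound 1 to compound 2 (0.34 log units; beyond the scatter) moved the number upward. Compound 4 is therefore estimated at 90000 nM, most likely again reported only as a limit, somewhere from 40000 nM to 250000 nM.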

Compound 4, half-maximal inhibitory concentration: > 40000 nM
Compound 4 gave a limit, no number; the forecaster's own chance of this, stated with the estimate: 85%; the middle value is on the limit's open side.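

Compound 3 and compound 4 are both reported only as limits, not as numbers, so the size of the step from ethynyl to chloro between them cannot be read: the limit of > 40000 nM in this assay, at which 2 of the 4 values shown sit. The compounds shown leave open whether this change shifts the number at all on the smaller core that compound 3 and compound 4 share.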